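The source may hold more compounds than are shown below. What is called first, only, known or untested is meant among the compounds shown, and "the series" means these compounds.

Among the measured compounds shown here, compound 1 `Fc1ccc(Sc2ncnc3[nH]cnc23)cc1` and compound 2 `Fc1ccc(Cn2cnc3c(Sc4ccccc4)ncnc32)cc1` share the same core, but differ in two places, so no single step connects them. In an assay on isolated protein for inhibition of Rho-associated protein kinase 1 (Homo sapiens), tested at 30 uM (a lower number here means less inhibition, a higher number more inhibition at the concentration tested (going by the name of the read-out)), compound 1 gives 37%. In the same assay compound 2 gives 2%, which is the lower of the two numbers recorded, and the gap between it and compound 1 lies beyond the usual scatter.

Compound 3 `Fc1ccc(Cn2cnc3c(Sc4ccc(F)cc4)ncnc32)cc1` is the next compound to be tested. It differs from compound 2 in one place only: fluoro in place of hydrogen on an aromatic carbon.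

For the measured compounds named here, no measured pair that differs in this single place exists here, so no step is known for this change. Compound 1 does carry the fluorine, but it also lacks the benzyl group, and its number cannot be attributed to either part. The step from compound 2 to compound 3 is therefore expected to be small, as a number 4 percentage points higher from compound 2 to compound 3 (within the scatter), and not beyond the scatter in either direction.

Compound 3 is accordingly expected to give about 6% in this assay, within a range from 0% to 18%.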

Compound 3, a percentage reported as inhibition, at one concentration (the size of the read-out at that concentration, not a potency): 0%
Beside the measured number, compound 3's estimate is 6 percentage points above it; low and high end bracket the measured number.
By their numbers in this assay, from the lowest: compounds 3 and 2 (each within the scatter of the next); then compound 1.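

In this assay the fluoro group on the aromatic carbon, para to a large group, gives a number 2 percentage points lower from compound 2 to compound 3 (within the scatter), so with the 4-fluorobenzyl group on the nitrogen in place, this position shows no change that can be told from the scatter. Among the compounds shown here, the other step, 4-fluorobenzyl in place of hydrogen on an aromatic nitrogen, gives a number 37 percentage points lower from compound 1 to compound 3 (beyond the scatter), and this is the first change in a single place to lie beyond the scatter, which ties the large gap in inhibition to the nitrogen substituent, at least in compounds carrying the fluoro group. No supporting measurement bears on why either step comes out as it does.

From the compounds shown here alone, with compound 3 at 0%, the fluoro step was read at the very bottom of the scale, so what the same change does on a compound keeping the free nitrogen hydrogen stays open. Also open, going by these compounds, are how a methoxy group or an amine would behave at that aromatic carbon, and whether a methyl group or a longer chain on the nitrogen would cost as much inhibition as the 4-fluorobenzyl group does.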